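This account rests on a few compounds, and the source may have more. Where it says the series, first, only, none or still open, it means among the compounds named here.

Compound 1 `Cc1ccc(C)c(N2CCN(C(=O)c3oc(C)nc3-c3ccccc3)CC2)c1`: 33.8%
Compound 2 `CCC[C@H](Nc1nc(-c2ccc(NC(=O)NCC)c(OC)c2)ncc1C)c1cccnc1`: 54.6%

In an ADME assay (liver) for metabolic stability, with Liver microsome (Homo sapiens) as the target, read by LC-MS, using microsomes, with a stated time of 1 h, tested at 5 uM (a higher number here means that more of the compound is left, a lower number that less of the compound is left), compound 1 gives 33.8%, the lower of the two numbers, and compound 2 lies beyond the scatter above it. Compound 3 `Cc1nc(-c2ccccc2)c(C(=O)N2CCN(c3cc(Cl)cc(Cl)c3)CC2)o1` keeps the core of compound 1 but changes one group: 3,5-dichlorophenyl in place of 2,5-dimethylphenyl on an amine nitrogen in a ring. That is 3,5-dichlorophenyl in place of 2,5-dimethylphenyl on an amine nitrogen in a ring. Among the compounds with values here, no measured pair shows this swap, so any forecast is uncertain. The expected change is a moderate rise, estimated as a number 11.2 percentage points higher from compound 1 to compound 3 (beyond the scatter). For compound 3, the expected value is 45%, with an estimated range of 22% to 68%.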

Compound 3, percent of the compound remaining: 66.3%
The estimate for compound 3 lay 21.3 percentage points below the measured number; the range from low to high includes it.
By their numbers in this assay, from the lowest: compound 1; then compound 2; then compound 3.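

At the piperazine-free wording of the data, this position is simply an amine nitrogen in a ring, and the group on it clearly matters in this assay. Putting 3,5-dichlorophenyl in place of 2,5-dimethylphenyl gives a number 32.5 percentage points higher from compound 1 to compound 3 (beyond the scatter), a large step between two groups with the same count of heavy atoms. Nothing at hand explains this step.

Open, on these data alone, is whether the step follows from the chlorine atoms or from their places on the ring. A 3,5-dimethylphenyl or plain phenyl group would help separate these two readings.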